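Series notes: phenyl substituent on the pyridazinone-type nitrogen

The source may report more compounds than this note shows. Statements on the series, on what has been measured and on what is new or still open speak of the compounds shown alone.

For the measured compounds named here, compound 2 `COc1cc2c(Oc3ccc(NC(=O)c4nn(-c5ccccc5OC(F)(F)F)c(=O)cc4C)cc3F)ccnc2cc1OCCCN1CCN(C)CC1` gives 130 nM in a functional assay on A549 cells (Homo sapiens) for inhibition, read by MTT assay, with a stated time of 72 h (on this read-out lower numbers stand for stronger inhibition and higher numbers for weaker inhibition), the lowest of the two numbers so far; its nearest neighbour is compound 1 `COc1cc2c(Oc3ccc(NC(=O)c4nn(-c5ccccc5C(F)(F)F)c(=O)cc4C)cc3F)ccnc2cc1OCCCN1CCN(C)CC1`, which gives 170 nM. The next compound, compound 3 `COc1cc2c(Oc3ccc(NC(=O)c4nn(-c5cccc(F)c5)c(=O)cc4C)cc3F)ccnc2cc1OCCCN1CCN(C)CC1`, carries 3-fluorophenyl in place of 2-(trifluoromethoxy)phenyl on an aromatic nitrogen. Going by the values given here, the only measured step, a 1.3-fold lower number from compound 1 to compound 2 (0.12 log units; within the scatter), changes the same phenyl group and stays within the scatter; it does not test the removal of a substituent at that ring position, so the expected size of the step is uncertain. The estimate for compound 3 is 200 nM, range 80 nM to 500 nM, meaning an expected step of a 1.5-fold higher number from compound 2 to compound 3 (0.19 log units; within the scatter).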

Compound 3, half-maximal inhibitory concentration: 150 nM
The estimate for compound 3 lay 1.3-fold (0.12 log units) above the measured number; the measured number falls inside the stated range.
By their numbers in this assay, from the lowest: compounds 2, 3 and 1 (each within the scatter of the next).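

In this assay, 3-fluorophenyl on the aromatic nitrogen gives a 1.2-fold higher number from compound 2 to compound 3 (0.06 log units; within the scatter) and a 1.1-fold lower number from compound 1 to compound 3 (0.05 log units; within the scatter). Both steps stay within the scatter, so a change in both the substituent and its place on the phenyl group separates none of the three compounds at this position. No supporting measurement bears on this result. Because both features change together, the contribution of each remains unresolved in these steps. Also open, from the compounds shown here alone, is whether the same holds with an amine or a carboxylic acid on the phenyl group.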